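Replacing the 4-methoxycyclohexyl group with oxan-4-yl

The source may hold more compounds than are shown below. What is called first, only, known or untested is meant among the compounds shown, and "the series" means these compounds.

Values in an ADME assay on S9 fraction from liver (Homo sapiens) for metabolic stability, with a stated time of 1 h; a higher number here means that more of the compound is left, a lower number that less of the compound is left:
- compound 1 `N#Cc1cnc(NCc2cnccc2C(F)(F)F)cc1NC[C@H]1C[C@H](O)C1` gives 93%
- compound 2 `N#Cc1cnc(NCc2cnccc2C(F)(F)F)cc1NC[C@H]1CC[C@H](O)CC1` gives 32%
- compound 3 `CO[C@H]1CC[C@@H](CNc2cc(NCc3cnccc3C(F)(F)F)ncc2C#N)CC1` gives 4%

Compound 3 stands lowest of the three, and its gaps to both others lie beyond the scatter. The next structure is compound 4 `N#Cc1cnc(NCc2cnccc2C(F)(F)F)cc1NC1CCOCC1`, and the change is oxan-4-yl in place of (4-methoxycyclohexyl)methyl on a nitrogen on an aromatic ring. In words, oxan-4-yl takes the place of (4-methoxycyclohexyl)methyl on a nitrogen on an aromatic ring.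

Going by the values given here, three measured steps bear on this change, all of them exchanges of the group at this same nitrogen. The step of a number 89 percentage points lower from compound 1 to compound 3 (beyond the scatter) is large, as is a number 61 percentage points lower from compound 1 to compound 2 (beyond the scatter), while a number 28 percentage points lower from compound 2 to compound 3 (beyond the scatter) is modest. Among these three compounds, the 4-methoxycyclohexyl group gives the lowest value and the 3-hydroxycyclobutyl group the highest, and none of the three goes against that order. None of them, however, has oxygen within the ring or lacks the chain carbon, so the transfer to compound 4 is uncertain.

A rise is still expected, resting on compound 1 and its large gap a number 89 percentage points lower from compound 1 to compound 3 (beyond the scatter). The expected change is a number 61 percentage points higher from compound 3 to compound 4 (beyond the scatter), which would be a large step upward. For compound 4 the estimate is 65%, with an expected range from 35% to 90%.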

Compound 4, percent of the compound remaining: 91%
The estimate for compound 4 lay 26 percentage points below the measured number, outside the stated range (above it).
By their numbers in this assay, from the lowest: compound 3; then compound 2; then compounds 4 and 1 (each within the scatter of the next).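

In this assay, the position proves able to carry a group with no hydroxyl: oxan-4-yl on the nitrogen gives a number 87 percentage points higher from compound 3 to compound 4 (beyond the scatter) and a number 59 percentage points higher from compound 2 to compound 4 (beyond the scatter), while a number 2 percentage points lower from compound 1 to compound 4 (within the scatter) leaves it level with the 3-hydroxycyclobutyl compound. Among these compounds, a hydrogen-bond donor in the group is therefore not needed for a high number, and an oxygen without a donor appears at both ends of the series, in the (4-methoxycyclohexyl)methyl of compound 3 and the oxan-4-yl of compound 4. No measured property accounts for this difference between the two groups.

The step from compound 3 to compound 4 changes the ring, the place of the oxygen and the chain carbon together, so the compounds shown do not say which of these carries it. An (oxan-4-yl)methyl group or a plain cyclohexyl group on the same nitrogen would separate the chain carbon from the ring oxygen, and a piperidin-4-yl group would show whether a ring amine behaves like the ring oxygen.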